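Methoxy for bromo on the aryl of compound 3

This account rests on a few compounds, and the source may have more. Where it says the series, first, only, none or still open, it means among the compounds named here.

Among the three compounds measured so far, compound 3 `O=C(O)CCC(=O)N1N=C(c2c(-c3ccc(Br)cc3)c3ccccc3[nH]c2=O)CC1c1ccc(Cl)cc1` stands lowest in an assay on cells (Oocyte) for negative allosteric modulation of glutamate receptor ionotropic, NMDA 2D (Rattus norvegicus), read by two-electrode voltage clamp (a lower number here means a stronger inhibitor, a higher number a weaker inhibitor), where compound 3 gives 290 nM. Compound 2 `O=C(O)CCC(=O)N1N=C(c2c(-c3ccccc3)c3cc(Cl)ccc3[nH]c2=O)CC1c1ccc([N+](=O)[O-])cc1` gives 1100 nM in this assay, and compound 1 `O=C(O)CCC(=O)N1N=C(c2c(-c3ccccc3)c3cc(Cl)ccc3[nH]c2=O)CC1c1ccc(Br)cc1` gives 3100 nM. Among the compounds with values here, the one single-point step available, a 2.8-fold lower number from compound 1 to compound 2 (0.45 log units; beyond the scatter), swaps bromo for nitro on an aromatic carbon and lowers the number modestly.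

Compound 4 `COc1ccc(-c2c(C3=NN(C(=O)CCC(=O)O)C(c4ccc(Cl)cc4)C3)c(=O)[nH]c3ccccc23)cc1` differs from compound 3 by methoxy in place of bromo on an aromatic carbon. The step from compound 1 to compound 2 is the only one touching a bromo on an aromatic carbon, but it replaces bromo with nitro, not methoxy, and on a different ring of the shared core, so it carries limited weight here. Within the data shown here, with no direct precedent, the replacement is expected to produce at most a small shift in this assay, either way, likely within or just beyond the scatter; the expected step is a 1.7-fold higher number from compound 3 to compound 4 (0.24 log units; within the scatter). Compound 4 is therefore estimated at 500 nM in this assay, with a range from 150 nM to 1600 nM.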

Compound 4, half-maximal inhibitory concentration: 2300 nM
Compound 4: middle estimate off by 4.6-fold (0.66 log units), on the low side, and the stated range ends below it.
By their numbers in this assay, from the lowest: compound 3; then compound 2; then compounds 4 and 1 (each within the scatter of the next).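

The swap of 4-bromophenyl to 4-methoxyphenyl is the first change shown at this position, and in this assay it gives a 7.9-fold higher number from compound 3 to compound 4 (0.90 log units; beyond the scatter), so the number responds to the group on this aromatic carbon. The earlier step, a 2.8-fold lower number from compound 1 to compound 2 (0.45 log units; beyond the scatter), also removed a bromo from an aromatic carbon, but on a different ring of the shared core and with nitro entering, and it ran the opposite way, so losing a bromo has no single direction across these compounds. Nothing measured here accounts for the size of the new step.

The compounds shown leave open whether bromo favours inhibition or methoxy disfavours it, a question that a plain phenyl, a fluoro, a methyl or a hydroxy at this place would help to settle. Also open, as far as these compounds go, is whether the step holds with a bromo or a nitro in place of the chloro on the other aryl.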